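Tetrazole for Oxadiazole in a Cytotoxicity Series

A few compounds are considered here, and "the series" means these few. Any claim that something is new, unique, unknown or untested is made for them only; others in the source may bear on it.

Compound 1: `CCCc1nc(-c2ccc(OCCC(C)CCN3CCN(c4ccncc4)C3=O)cc2)no1` gives > 12500 nM
Compound 2: `CCc1nc(-c2ccc(OCCC(C)CCN3CCN(c4ccncc4)C3=O)cc2)no1` gives > 25000 nM

In an ADME assay on cells (Homo sapiens) for cytotoxicity (a lower number here means that less compound is tolerated, a higher number that more compound is tolerated), compound 1 reaches only a limit, (the limit of > 12500 nM in this assay, at which 1 of the 2 values shown sits), and not a number. In this assay compound 2 likewise reaches only a limit, (the limit of > 25000 nM in this assay, at which 1 of the 2 values shown sits), so compound 2 stands at the upper edge of what the measurement can report. Among the compounds with values here, the one measured step, a step that the two limits leave unreadable from compound 1 to compound 2, is therefore unreadable in size, since both ends are limits. Compound 3, `CC(CCOc1ccc(-c2nnn(C)n2)cc1)CCN1CCN(c2ccncc2)C1=O`, carries the change (2-methyl-2H-tetrazol-5-yl in place of 5-ethyl-1,2,4-oxadiazol-3-yl on an aromatic carbon), which replaces the five-membered ring with three hetero atoms by a five-membered ring with four hetero atoms on the ring carbon para to a large group. No measured step touches this change directly, and the only step shown sets no scale. The account thus expects no step beyond the scatter in this assay, and the expected step that the limit leaves unreadable from compound 2 to compound 3 from compound 2 is written as flat. For compound 3 the estimate in this assay is 30000 nM, with a range from 10000 nM to 100000 nM, most likely reported again only as a limit.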

Compound 3, half-maximal cytotoxic concentration: > 25000 nM
Compound 3: no number, only a limit; the forecaster's own chance of this, stated with the estimate: 80%; the middle value does not contradict the limit.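

In this assay compound 3 gives > 25000 nM, which is a limit and not a number. Within the data shown here, compound 1, compound 2 and compound 3 all stand at limits, and no step among them can be read. The compounds shown leave open whether 2-methyl-2H-tetrazol-5-yl in place of 5-ethyl-1,2,4-oxadiazol-3-yl changes the tolerated concentration at all.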